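Hydrazone-type arm on the urea nitrogen of compound 2

This account rests on a few compounds, and the source may have more. Where it says the series, first, only, none or still open, it means among the compounds named here.

Two compounds of the series carry numbers in a functional assay on MCF7 cells (Homo sapiens) for antiproliferative activity, read by MTT assay; a higher number here means a weaker inhibitor, a lower number a stronger inhibitor. Compound 1 `COc1cc2c(Oc3ccc(NC(=O)Nc4ccc(OC(F)(F)F)cc4)cc3)ccnc2cc1OCCCCCCC(=O)NO` gives 3200 nM. Among the measured compounds shown here, compound 2 `COc1cc2c(Oc3ccc(NC(=O)Nc4ccccc4F)cc3)ccnc2cc1OCCCCCCC(=O)NO` gives 660 nM, the lowest of the two numbers; the single measured step, a 4.8-fold lower number from compound 1 to compound 2 (0.69 log units; beyond the scatter), lies beyond the scatter. Compound 3 `COc1cc2c(Oc3ccc(NC(=O)N/N=C/c4ccccc4F)cc3)ccnc2cc1OCCCCCCC(=O)NO` is not yet measured. Its difference from compound 2 is a group of 9 heavy atoms (7 carbon, 1 nitrogen, 1 fluorine; one six-membered aromatic ring of carbon only) in place of a group of 7 heavy atoms (6 carbon, 1 fluorine; one six-membered aromatic ring of carbon only), on an amide-type nitrogen: the entering group carries one double bond outside aromatic rings and one hydrogen-bond acceptor, and sits on the amide-type nitrogen next to the carbonyl carbon. For the measured compounds named here, the one measured step exchanges one aryl group for another and does not directly cover an insertion of this kind, so the expectation rests on little. Compound 3 is expected to show a step of a 1.7-fold higher number from compound 2 to compound 3 (0.22 log units; within the scatter) of no more than modest size, most likely toward a somewhat higher number. Compound 3 is therefore estimated at 1100 nM, within 300 nM to 4000 nM.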

Compound 3, half-maximal inhibitory concentration: 1610 nM
Compound 3: middle estimate off by 1.5-fold (0.17 log units), on the low side, and the stated range covers the measured number.
By their numbers in this assay, from the lowest: compound 2; then compounds 3 and 1 (each within the scatter of the next).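

In this assay, the longer arm on the amide-type nitrogen keeps the fluorinated aromatic ring and adds a double bond outside aromatic rings, and this gives a 2.4-fold higher number from compound 2 to compound 3 (0.39 log units; beyond the scatter). The position therefore accepts more than a directly attached aryl group, at a modest cost beyond the scatter relative to 2-fluorophenyl. Against the 4-(trifluoromethoxy)phenyl group the same arm gives a 2.0-fold lower number from compound 1 to compound 3 (0.30 log units; within the scatter), within the scatter, so compound 3 and compound 1 cannot be ordered, and nothing available explains either step.

Open, from the compounds shown here alone, is whether the step comes from the inserted link or from how it presents the fluorinated ring. A saturated methylene link in place of the double bond, or a plain phenyl or pyridine ring at the end of the arm, would separate these readings.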